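From 2,4-dimethoxyphenyl to 3-chlorophenyl on the shared core

The source may hold more compounds than are shown below. What is called first, only, known or untested is meant among the compounds shown, and "the series" means these compounds.

Of the compounds shown here, two have numbers so far. In a functional assay on BT-474 cells (Homo sapiens) for inhibition, read by fluorescence, with a stated time of 72 h (on this read-out higher numbers stand for weaker inhibition of growth and lower numbers for stronger inhibition of growth), compound 1 (`COc1ccc(Nc2nc(N[C@H]3CC[C@H](N)CC3)nc3c2ncn3CCC(C)C)c(OC)c1`) gives 7900 nM, and compound 2 (`N[C@H]1CC[C@H](Nc2nc(Nc3ccc(O)cc3)c3ncn(C4CCCCC4)c3n2)CC1`) gives 27300 nM. Compound 1 thus stands at the lower of the two numbers, with a gap to compound 2 that lies beyond the scatter. For the measured compounds named here, no measured pair isolates a single change, so the series offers no direct precedent for the next step.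

Compound 3 (`CC(C)CCn1cnc2c(Nc3cccc(Cl)c3)nc(N[C@H]3CC[C@H](N)CC3)nc21`) keeps the core of compound 1. The one difference is 3-chlorophenyl in place of 2,4-dimethoxyphenyl on a nitrogen on an aromatic ring, and it sits on a nitrogen on an aromatic ring. Going by the values given here, with no measured step to draw on, the working assumption is a modest move at most. The expected result in this assay is a 1.3-fold lower number from compound 1 to compound 3 (0.12 log units; within the scatter), an estimated shift toward stronger inhibition of growth that stays within the scatter. The uncertainty is wide, and a move in either direction remains possible. Compound 3 is estimated at 6000 nM, with an expected range from 2000 nM to 20000 nM.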

Compound 3, concentration for 50% growth inhibition: 3800 nM
For compound 3 the middle estimate is 1.6-fold (0.20 log units) above the measured one, within the range that was stated.
By their numbers in this assay, from the lowest: compound 3; then compound 1; then compound 2.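

For the compounds shown here, this is the first measured step that isolates a single change. In this assay, 3-chlorophenyl in place of 2,4-dimethoxyphenyl on a nitrogen on an aromatic ring gives a 2.1-fold lower number from compound 1 to compound 3 (0.32 log units; beyond the scatter) and moves the read-out toward stronger inhibition of growth, so the aromatic group at this position can be exchanged without a loss of growth inhibition, and the two methoxy groups are not required for it in this pair. No supporting measurement is available to explain the step, which remains a single observation at this position.

The compounds shown leave open whether the shift belongs to the arrival of the chlorine or to the departure of the methoxy groups, a question that a plain phenyl on the same nitrogen would address directly. Also open, going by these compounds, is how widely this position accepts other groups, such as a 3-fluorophenyl, a 3-methoxyphenyl or a phenyl carrying a carboxylic acid, and whether any of them would take growth inhibition further than the modest step seen here.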